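The source may hold more compounds than are shown below. What is called first, only, known or untested is meant among the compounds shown, and "the series" means these compounds.

Working notes, series of the shared core of compound 1 `OC[C@H](NC1CCN(CCCc2c[nH]c3ccc(-n4ccnc4)cc23)CC1)c1ccccc1`. In an assay on CHO cells for displacement of a labelled ligand from 5-hydroxytryptamine receptor 1D (Homo sapiens) (on this read-out lower numbers stand for stronger inhibition and higher numbers for weaker inhibition), compound 1 gives 0.7 nM. Compound 3 `C[C@@H](NC1CCN(CCCc2c[nH]c3ccc(-n4ccnc4)cc23)CC1)c1ccccc1`, which carries 1-phenylethyl in place of 2-hydroxy-1-phenylethyl on the amine nitrogen, gives 4.2 nM in this assay; the step from compound 1 to compound 3 is a 6.0-fold higher number from compound 1 to compound 3 (0.78 log units; beyond the scatter). Compound 2 `O[C@@H]1Cc2ccccc2[C@H]1NC1CCN(CCCc2c[nH]c3ccc(-n4cnnc4)cc23)CC1` gives 6.6 nM in this assay, the highest number of the three measured; its gap to compound 3 lies within the scatter, its gap to compound 1 beyond it.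

Compound 4 `c1ccc2c(c1)CCC2NCC1CCN(CCCc2c[nH]c3ccc(-n4cnnc4)cc23)CC1` is not yet measured. It differs from compound 2 by ((2,3-dihydro-1H-inden-1-yl)amino)methyl in place of (2-hydroxy-2,3-dihydro-1H-inden-1-yl)amino on a saturated ring carbon. Within the data shown here, the one measured step that bears on this, from compound 1 to compound 3, also set a group without the hydroxy in place of one carrying it, and it weakened binding; no measured pair covers the added methylene between the saturated ring carbon and the amine. A step in the same direction is therefore expected, roughly of the size seen from compound 1 to compound 3, with wide uncertainty: a 3.3-fold higher number from compound 2 to compound 4 (0.52 log units; beyond the scatter). Compound 4 is expected to give about 22 nM in this assay, in the range 6 nM to 90 nM.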

Compound 4, half-maximal inhibitory concentration: 1.1 nM
The estimate for compound 4 lay 20-fold (1.30 log units) above the measured number, and the stated range ends above it.
By their numbers in this assay, from the lowest: compounds 1 and 4 (each within the scatter of the next); then compounds 3 and 2 (each within the scatter of the next).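

In this assay, the change on the saturated ring carbon, three ring bonds from the ring nitrogen, gives a 6.0-fold lower number from compound 2 to compound 4 (0.78 log units; beyond the scatter), so a group without the hydroxy is not tied to weaker binding in this series. The direction is opposite to that of a 6.0-fold higher number from compound 1 to compound 3 (0.78 log units; beyond the scatter), where the change on the amine nitrogen involves the hydroxy but no added methylene. No available evidence explains this difference.

The step from compound 2 to compound 4 combines loss of the hydroxy with the added methylene, so the compounds shown cannot apportion it; (2,3-dihydro-1H-inden-1-yl)amino and ((2-hydroxy-2,3-dihydro-1H-inden-1-yl)amino)methyl on the same carbon would separate the two. Also open, on these data alone, is how a longer chain, such as ((2,3-dihydro-1H-inden-1-yl)amino)ethyl, would read at this position.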